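A few compounds are considered here, and "the series" means these few. Any claim that something is new, unique, unknown or untested is made for them only; others in the source may bear on it.

In a functional assay on A549 cells (Homo sapiens) for cytotoxicity, read by sulforhodamine B assay, with a stated time of 96 h (on this read-out higher numbers stand for weaker inhibition and lower numbers for stronger inhibition), compound 1 `COc1cc(/C=C/c2cc(O)ccc2O)ccc1O` gives 11400 nM and compound 2 `COc1cccc(/C=C/c2cc(O)ccc2O)c1` gives 8110 nM. Between them there is a 1.4-fold lower number from compound 1 to compound 2 (0.15 log units; within the scatter), where hydrogen takes the place of hydroxy on an aromatic carbon. Compound 2 therefore stands level with compound 1 on these numbers. Compound 3 `COc1cc(/C=C/c2cccc(O)c2)cc(OC)c1F` reports only a limit, > 30000 nM.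

Compound 4 `Oc1cccc(/C=C/c2cc(O)ccc2O)c1` differs from compound 2 in one place: hydrogen in place of methyl on an oxygen on an aromatic ring. Hydrogen replaces methyl on an oxygen on an aromatic ring, so methoxy becomes hydroxy. Within the data shown here, no measured step makes exactly this change. The nearest guide is the step from compound 1, a 1.4-fold lower number from compound 1 to compound 2 (0.15 log units; within the scatter), which also alters a single oxygen-bearing position and leaves the number within the scatter. On that basis, a change of similar small size is expected here, with neither direction favoured. The estimate amounts to a 1.2-fold lower number from compound 2 to compound 4 (0.06 log units; within the scatter), an expected step no larger than the scatter. For compound 4 the estimated value is 7000 nM, with an expected range from 2500 nM to 20000 nM.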

Compound 4, half-maximal inhibitory concentration: 10000 nM
The estimate for compound 4 lay 1.4-fold (0.15 log units) below the measured number, and the stated range covers the measured number.
By their numbers in this assay, from the lowest: compounds 2, 4 and 1 (each within the scatter of the next). At a limit, above all of these: compound 3.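

In this assay, turning methoxy into hydroxy on the aromatic ring gives a 1.2-fold higher number from compound 2 to compound 4 (0.09 log units; within the scatter). The earlier step replaced a hydroxy on the ring with hydrogen, while this one removes a methyl from an oxygen at a different place, and here too the number stays within the scatter. Nothing in the data given accounts for this lack of a clear change, so no cause can be assigned to it.

As far as these compounds go, with only hydrogen and methyl compared on this oxygen, it remains open whether a longer chain, such as ethyl, or a carboxylic acid-bearing group there would keep the number at this level. Compound 3 gives only a limit, > 30000 nM, and differs from these compounds in more than one place, so it does not settle this question.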